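The compounds below may be only part of what the source reports. "The series", "measured", "known", "first", "only" and "open" are said of these compounds alone.

Compound 1 `C#Cc1cn([C@@H]2O[C@H](CO)[C@@H](O)[C@H]2O)c2ncnc(OC)c12`: in a functional assay on CCRF-CEM cells (Homo sapiens), read by MTT assay, with a stated time of 72 h (on this read-out higher numbers stand for weaker inhibition and lower numbers for stronger inhibition), compound 1 gives > 20000 nM, which is a limit of the assay and not a number.
Compound 2 `COc1ncnc2c1c(-c1ccccc1)cn2[C@@H]1O[C@H](CO)[C@@H](O)[C@H]1O`: in this assay compound 2 gives > 20000 nM, again a limit of the assay.
Compound 3 `COc1ncnc2c1c(-c1ccco1)cn2[C@@H]1O[C@H](CO)[C@@H](O)[C@H]1O`: in this assay compound 3 gives 20 nM.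

Among the compounds with values here, compound 3 therefore holds the only number among the three; the other two sit at the limit of > 20000 nM in this assay, at which 2 of the 3 values shown sit. Replacing the ethynyl with furan-2-yl gives an at least 1000-fold lower number from compound 1 to compound 3 (3.00 log units; beyond the scatter), and replacing the phenyl with furan-2-yl gives an at least 1000-fold lower number from compound 2 to compound 3 (3.00 log units; beyond the scatter), while a step that the two limits leave unreadable from compound 1 to compound 2 cannot be sized since both of its values are limits.

Compound 4 `COc1ncnc2c1c(-c1ccsc1)cn2[C@@H]1O[C@H](CO)[C@@H](O)[C@H]1O` differs from compound 3 in one place: thiophen-3-yl in place of furan-2-yl on an aromatic carbon. Within the data shown here, no measured step swaps one five-membered ring for another, so the two large steps only show that a furan-2-yl and a phenyl or ethynyl group lie far apart in this assay. The thiophen-3-yl group keeps a five-membered ring with one hetero atom, so for compound 4 a moderate weakening is expected, a 10-fold higher number from compound 3 to compound 4 (1.00 log units; beyond the scatter). Compound 4 is estimated at 200 nM, within a range of 20 nM to 5000 nM.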

Compound 4, half-maximal inhibitory concentration: 2570 nM
Compound 4: the middle estimate sits 13-fold (1.11 log units) below what was measured, and the stated range covers the measured number.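

In this assay, this position separates two groups that match in heavy atoms, ring size and hydrogen-bond donors and acceptors: thiophen-3-yl in place of furan-2-yl gives a 130-fold higher number from compound 3 to compound 4 (2.11 log units; beyond the scatter). A five-membered aromatic ring with one hetero atom is therefore not enough on its own to keep the low number of compound 3. Replacing phenyl or ethynyl with thiophen-3-yl still gives an at least 7.7-fold lower number from compound 2 to compound 4 (0.89 log units; beyond the scatter) and an at least 7.7-fold lower number from compound 1 to compound 4 (0.89 log units; beyond the scatter), and both steps are only minimum sizes: the limit of > 20000 nM in this assay, at which 2 of the 4 values shown sit.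

The change from furan-2-yl to thiophen-3-yl swaps oxygen for sulfur and also changes which ring atom carries the bond to the shared core, so the compounds shown cannot say which of the two matters. A thiophen-2-yl or furan-3-yl group at this place would separate them.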